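This account rests on a few compounds, and the source may have more. Where it says the series, first, only, none or still open, it means among the compounds named here.

Measured so far in a functional assay on MDA-MB-231 cells (Homo sapiens) for cytotoxicity, with a stated time of 48 h; on this read-out lower numbers stand for stronger inhibition and higher numbers for weaker inhibition:
compound 1 `O=[N+]([O-])c1ccc(CN2CCC(n3cc(CC(OCc4cc(-c5ccc(F)cc5)no4)c4ccc(Br)cc4)nn3)CC2)cc1` gives > 25000 nM, a limit of the assay.
compound 2 `COc1cccc(-c2cc(COC(Cc3cn(C4CCN(Cc5ccc([N+](=O)[O-])cc5)CC4)nn3)c3ccc(Br)cc3)on2)c1` gives > 25000 nM, a limit of the assay.
compound 3 `N#Cc1cccc(-c2cc(COC(Cc3cn(C4CCN(Cc5ccc([N+](=O)[O-])cc5)CC4)nn3)c3ccc(Br)cc3)on2)c1` gives > 25000 nM, a limit of the assay.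

Compound 3 therefore stands at the limit, like every value in the set (the limit of > 25000 nM in this assay, at which 3 of the 3 values shown sit). The three aryl swaps on the shared core, a step that the two limits leave unreadable from compound 1 to compound 2, a step that the two limits leave unreadable from compound 1 to compound 3 and a step that the two limits leave unreadable from compound 2 to compound 3, are all unreadable, since both ends sit at the limit.

Compound 4 `O=[N+]([O-])c1ccc(CN2CCC(n3cc(CC(OCc4cc(-c5ccccc5F)no4)c4ccc(Br)cc4)nn3)CC2)cc1` brings the change (2-fluorophenyl in place of 3-cyanophenyl on an aromatic carbon). The measured steps that bear on it are the same aryl swaps, none of which shows a readable size, so no step beyond the scatter can be derived in this assay ; the expectation is that compound 4 also falls at the limit. Compound 4 is estimated at 30000 nM, with a range from 15000 nM to 100000 nM, meaning an expected step that the limit leaves unreadable from compound 3 to compound 4.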

Compound 4, half-maximal inhibitory concentration: 4000 nM
Compound 4: the middle estimate sits 7.5-fold (0.88 log units) above what was measured; measured number below the stated range.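

In this assay this position gives the series its first readable steps: 2-fluorophenyl in place of 3-cyanophenyl gives an at least 6.2-fold lower number from compound 3 to compound 4 (0.79 log units; beyond the scatter), and in place of 3-methoxyphenyl it gives an at least 6.2-fold lower number from compound 2 to compound 4 (0.79 log units; beyond the scatter). Even 2-fluorophenyl in place of 4-fluorophenyl, a change of fluorine placement on the same phenyl, gives an at least 6.2-fold lower number from compound 1 to compound 4 (0.79 log units; beyond the scatter). All three sizes are minimum sizes, set by the limit: the limit of > 25000 nM in this assay, at which 3 of the 4 values shown sit.

From the compounds shown here alone, whether the gain needs fluorine stays open, since 2-chlorophenyl or 2-methoxyphenyl on this carbon would test that. Going by these compounds, the true distance of compound 1, compound 2 and compound 3 from compound 4 also remains unknown.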